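The compounds below may be only part of what the source reports. "The series", "measured", "known", "first", "only" and "open" are said of these compounds alone.

Among the measured compounds shown here, in a functional assay on MCF7 cells (Homo sapiens) for inhibition, read by MTT assay, with a stated time of 48 h (on this read-out lower numbers stand for stronger inhibition and higher numbers for weaker inhibition), compound 3 `O=[N+]([O-])c1ccc(C(c2c[nH]c3ccc([N+](=O)[O-])cc23)c2c[nH]c3ccc([N+](=O)[O-])cc23)cc1` gives 22500 nM, the only actual number among the three compounds measured. Compound 1 `O=[N+]([O-])c1ccc2[nH]cc(C(c3ccc(Cl)cc3)c3c[nH]c4ccc([N+](=O)[O-])cc34)c2c1` reaches only a limit of the assay, > 100000 nM. Compound 2 `O=[N+]([O-])c1ccc2[nH]cc(C(c3ccc(Br)cc3)c3c[nH]c4ccc([N+](=O)[O-])cc34)c2c1` likewise reaches only a limit, > 100000 nM. Between these two, the data show a step that the two limits leave unreadable from compound 1 to compound 2.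

The next structure, compound 4 `CCCCCCCC(c1c[nH]c2ccc([N+](=O)[O-])cc12)c1c[nH]c2ccc([N+](=O)[O-])cc12`, has heptyl in place of 4-nitrophenyl on a saturated chain carbon bound to two aromatic carbons.

For the measured compounds named here, two measured steps bear on this change, both at the same aromatic group: an at least 4.4-fold lower number from compound 1 to compound 3 (0.64 log units; beyond the scatter), with nitro in place of chloro, and an at least 4.4-fold lower number from compound 2 to compound 3 (0.64 log units; beyond the scatter), with nitro in place of bromo. Going by the values given here, compound 4 also lacks that nitro, so a higher number is expected, although no measured compound carries a chain and the size remains uncertain. The expected change is a 2.7-fold higher number from compound 3 to compound 4 (0.43 log units; beyond the scatter). Compound 4 is estimated at 60000 nM, with an expected range of 15000 nM to 200000 nM.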

Compound 4, half-maximal inhibitory concentration: 5800 nM
Compound 4: middle estimate off by 10-fold (1.01 log units), on the high side; measured number outside the range, below it.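

At this saturated chain carbon bound to two aromatic carbons, an aromatic ring is not needed for activity: heptyl in place of 4-nitrophenyl gives a 3.9-fold lower number from compound 3 to compound 4 (0.59 log units; beyond the scatter). The nitro-bearing ring therefore no longer marks the lowest number in the set, and the same chain in place of 4-bromophenyl and 4-chlorophenyl gives an at least 17-fold lower number from compound 2 to compound 4 (1.23 log units; beyond the scatter) and an at least 17-fold lower number from compound 1 to compound 4 (1.23 log units; beyond the scatter). These two larger steps are bounds and not exact sizes, set by a limit of the assay: the limit of > 100000 nM in this assay, at which 2 of the 4 values shown sit.

Heptyl is the only chain shown, so it remains open whether a shorter chain such as butyl or a longer chain such as decyl would lower the number further. From the compounds shown here alone, it is also open how a chain ending in an amine or a carboxylic acid, or a plain phenyl, would compare.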